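Ring-nitrogen methylation in a bridged amine series

The compounds below may be only part of what the source reports. "The series", "measured", "known", "first", "only" and "open" are said of these compounds alone.

Compound 1 `C1=C(c2cccnc2)C[C@@H]2CNC[C@H]1C2` is the parent of this set. In an in vitro functional assay on SH-SY5Y cells for agonist activity at Neuronal acetylcholine receptor; alpha3/beta4 (Homo sapiens), read by FLIPR and calcium flux (on this read-out lower numbers stand for smaller maximal responses and higher numbers for larger maximal responses), compound 1 gives 139%. Compound 2 `CN1C[C@@H]2C=C(c3cccnc3)C[C@@H](C2)C1` carries one change from compound 1, (methyl in place of hydrogen on an amine nitrogen in a ring), and in this assay compound 2 gives 25%. The resulting step is a number 114 percentage points lower from compound 1 to compound 2 (beyond the scatter). Compound 3 `CC(C)Oc1cncc(C2=CC3CNCC(C2)C3)c1` has a different core; the difference between the core of compound 3 and that of compound 1 is not broken down here. In this assay compound 3 gives 160%, the highest of the three measured values. Compound 4 `CC(C)Oc1cncc(C2=CC3CC(C2)CN(C)C3)c1` has not yet been measured. It differs from compound 3 by methyl in place of hydrogen on an amine nitrogen in a ring, which is the same change as that from compound 1 to compound 2, at the same place in the ring system. Because the earlier step was a number 114 percentage points lower from compound 1 to compound 2 (beyond the scatter), the step from compound 3 to compound 4 is expected to be a number 115 percentage points lower from compound 3 to compound 4 (beyond the scatter), allowing for the different core. Compound 4 is therefore estimated at 45%. For compound 4 the expected span runs from 15% to 95%.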

Compound 4, largest response reached (reported as percent of maximum), in percent of the reference or control that the assay uses: 15%
Compound 4: middle estimate off by 30 percentage points, on the high side; the measured number falls inside the stated range.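

In this assay methyl in place of hydrogen on an amine nitrogen in a ring again brings a large fall, with a number 145 percentage points lower from compound 3 to compound 4 (beyond the scatter), so the direction of the change carries from the core of compound 1 to the core of compound 3. These two pairs show only that shared direction; they do not establish a rule for other cores, and they do not show which feature of the two cores goes with the difference in size. The size itself does not carry over unchanged, as the two steps show: the same change on two cores in this assay, a number 114 percentage points lower (beyond the scatter) from compound 1 to compound 2 and a number 145 percentage points lower (beyond the scatter) from compound 3 to compound 4, 31 percentage points apart, beyond the scatter of two such steps.

The compounds shown leave open whether an ethyl group or a longer chain on the amine nitrogen would lower the response as methyl does. They also leave open how the same change would behave on a third core, and whether a step of this kind would appear at other receptors.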